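Adding a Third Methoxy Group on the Carbonyl-Side Ring

The source may report more compounds than this note shows. Statements on the series, on what has been measured and on what is new or still open speak of the compounds shown alone.

Of the compounds shown here, two have been measured in a functional assay on OVCAR-8 cells (Homo sapiens) for cytotoxicity, read by sulforhodamine B assay, with a stated time of 48 h, tested at 1 uM; a lower number here means a stronger effect, a higher number a weaker effect of the compound at the concentration tested. Compound 1 `COc1cc(-c2cc(/C=C/C(=O)c3ccc(Cl)c(Cl)c3)[nH]n2)cc(OC)c1OC` gives 88% in this assay. Compound 2 `COc1ccc(C(=O)/C=C/c2cc(-c3cc(OC)c(OC)c(OC)c3)n[nH]2)cc1OC` gives 69%, and this is the lowest of the two numbers, so compound 2 shows the stronger effect of the pair. Among the compounds with values here, the only measured step, a number 19 percentage points lower from compound 1 to compound 2 (beyond the scatter), comes from a change of the whole ring on the carbonyl carbon and is beyond the scatter.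

Compound 3 `COc1cc(C(=O)/C=C/c2cc(-c3cc(OC)c(OC)c(OC)c3)n[nH]2)cc(OC)c1OC` has not yet been measured. It differs from compound 2 by methoxy in place of hydrogen on an aromatic carbon, so the ring on the carbonyl carbon now carries three methoxy groups. Within the data shown here, no measured step concerns adding a single methoxy group at this place; the step from compound 1 to compound 2 only shows that this ring can shift the read-out by a modest amount. With so little to go on, compound 3 is expected to stay close to compound 2, with a step of a number 4 percentage points lower from compound 2 to compound 3 (within the scatter) that lies within the scatter. The estimate for compound 3 is therefore 65%, with a range from 45% to 85%.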

Compound 3, a percentage reported as activity, at one concentration (the size of the read-out at that concentration, not a potency): 81%
The estimate for compound 3 lay 16 percentage points below the measured number; the range from low to high includes it.
By their numbers in this assay, from the lowest: compound 2; then compounds 3 and 1 (each within the scatter of the next).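

In this assay the added methoxy group gives a number 12 percentage points higher from compound 2 to compound 3 (beyond the scatter) and so a weaker effect of the compound at the concentration tested. The earlier step replaced a whole ring, whereas this one shows that a single methoxy in place of hydrogen on this aromatic carbon, ortho to a methoxy group, is enough to move the read-out beyond the scatter, and that the lower number seen with a number 19 percentage points lower from compound 1 to compound 2 (beyond the scatter) does not continue when this ring gains a third methoxy group. Nothing available explains why this single change weakens the effect.

The compounds shown leave open whether the weaker effect comes from methoxy in particular or would also follow from another group on this carbon, such as a fluorine, a hydroxyl or a longer chain like ethoxy. They also leave open whether the same change would act in the same way on a ring carrying other groups, and a read-out at one concentration gives no potency for any of these compounds.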